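Carbonyl to Sulfonyl on a Shorter Chain

The source may report more compounds than this note shows. Statements on the series, on what has been measured and on what is new or still open speak of the compounds shown alone.

compound 1 `Cc1ccc(S(=O)(=O)NCCCNc2nccc(-c3c(-c4cccc(F)c4)nc4sccn34)n2)cc1` — 8380 nM
compound 2 `O=C(NCCCNc1nccc(-c2c(-c3cccc(F)c3)nc3sccn23)n1)c1ccc(F)cc1` — 14900 nM

In a functional assay on A-375 cells (Homo sapiens) for cytotoxicity, read by MTT assay (a lower number here means a stronger inhibitor, a higher number a weaker inhibitor), compound 1 gives 8380 nM, and compound 2 gives 14900 nM. For the measured compounds named here, the only measured step is a 1.8-fold higher number from compound 1 to compound 2 (0.25 log units; within the scatter), so compound 2 holds the highest of the two numbers, yet it sits within the scatter of compound 1 and the two cannot be ordered.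

Compound 3 `O=S(=O)(NCCNc1nccc(-c2c(-c3cccc(F)c3)nc3sccn23)n1)c1ccc(F)cc1` differs from compound 2 by ((4-fluorophenyl)sulfonyl)amino in place of (((4-fluorophenyl)carbonyl)amino)methyl on a saturated chain carbon, two bonds along the chain from a nitrogen on an aromatic ring. The step from compound 1 to compound 2 bears on this in part, since it exchanged a sulfonyl for a carbonyl on the same chain nitrogen and stayed within the scatter. Going by the values given here, no measured pair speaks to the shorter chain, so that part is unknown. The expected step is therefore a 1.5-fold lower number from compound 2 to compound 3 (0.17 log units; within the scatter), none beyond the scatter. Compound 3 is estimated at 10000 nM, with a range from 3000 nM to 30000 nM.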

Compound 3, half-maximal inhibitory concentration: 9450 nM
The estimate for compound 3 lay 1.1-fold (0.02 log units) above the measured number, within the range that was stated.
By their numbers in this assay, from the lowest: compounds 1, 3 and 2 (each within the scatter of the next).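

In this assay, the exchange of the (((4-fluorophenyl)carbonyl)amino)methyl group for ((4-fluorophenyl)sulfonyl)amino gives a 1.6-fold lower number from compound 2 to compound 3 (0.20 log units; within the scatter), so this replacement, which also shortens the chain, does not separate the two compounds. Replacing (((4-methylphenyl)sulfonyl)amino)methyl with ((4-fluorophenyl)sulfonyl)amino at the same place gives a 1.1-fold higher number from compound 1 to compound 3 (0.05 log units; within the scatter), which also stays within the scatter. The compound with the shorter chain therefore cannot be ordered against either compound with the longer chain.

Going by these compounds, the effect of chain length alone stays open, as each step to compound 3 also alters the group at the chain end. Also open, on these data alone, is whether a longer chain, or an amine or carboxylic acid at the chain end, would give a number beyond the scatter. No evidence on hand explains these results.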